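The source may report more compounds than this note shows. Statements on the series, on what has been measured and on what is new or still open speak of the compounds shown alone.

Notes on the series

Two compounds of this set have numbers in a functional assay on MDA-MB-231 cells (Homo sapiens) for antiproliferative activity, read by MTT assay, with a stated time of 48 h; a higher number here means a weaker inhibitor, a lower number a stronger inhibitor. Compound 1, `CCOC(=O)CN(Cc1ccccc1)c1nc(NCc2cccc(OC)c2)ncc1[N+](=O)[O-]`, gives 80700 nM in this assay. Compound 2, `COC(=O)CN(C)c1nc(Nc2ccc(Cl)cc2)ncc1[N+](=O)[O-]`, gives 21200 nM in this assay, the lowest of the two numbers; the gap to compound 1 lies beyond the usual scatter. Compounds 1 and 2 differ in more than one place, so no single step can be read from them.

Compound 3, `COC(=O)CN(C)c1nc(NCc2ccccc2)ncc1[N+](=O)[O-]`, is not yet measured. It differs from compound 2 in one place: benzyl in place of 4-chlorophenyl on a nitrogen on an aromatic ring. Going by the values given here, no measured pair in the set isolates this change, so the direction rests on the two numbers alone, and the benzylamino-bearing compound 1 gives the higher number. A step toward a higher number is expected, of a size around the edge of the scatter, as a 1.7-fold higher number from compound 2 to compound 3 (0.22 log units; within the scatter). Compound 3 is therefore estimated at 35000 nM in this assay, with a range from 15000 nM to 90000 nM.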

Compound 3, half-maximal inhibitory concentration: 61100 nM
Compound 3: the middle estimate sits 1.7-fold (0.24 log units) below what was measured, and the stated range covers the measured number.
By their numbers in this assay, from the lowest: compound 2; then compounds 3 and 1 (each within the scatter of the next).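

Going by these compounds alone, the swap of 4-chlorophenyl for benzyl on a nitrogen on an aromatic ring gives the first single-place reading: in this assay, a 2.9-fold higher number from compound 2 to compound 3 (0.46 log units; beyond the scatter), so this position responds to the change, and the step lies beyond the scatter. Both groups carry one six-membered aromatic ring of carbon only and no hydrogen-bond donors or acceptors, so the change in these counts lies in the chlorine and in the carbon that sets the ring one bond further out. No measurement in hand bears on the origin of this step.

The compounds shown do not separate the chlorine from that added carbon; a plain phenyl or a 4-chlorobenzyl group at this position would do so. From the compounds shown here alone, compound 1 differs from compound 3 in more than one place, so no step can be read between them, and the ester end remains open, for example a carboxylic acid in place of the methyl ester.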